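Working notes: methyl in place of chloro on compound 1

A few compounds are considered here, and "the series" means these few. Any claim that something is new, unique, unknown or untested is made for them only; others in the source may bear on it.

compound 1 `O=C(CNC(=O)c1nn(-c2ccccc2)c(=O)c2ccccc12)Nc1nc2ccc(Cl)cc2s1` — 30 nM
compound 2 `COc1ccc(-n2nc(C(=O)NCC(=O)Nc3nc4ccc(Cl)cc4s3)c3ccccc3c2=O)cc1` — 15 nM

Both numbers come from an assay on L cells for inhibition of Protein-serine O-palmitoleoyltransferase porcupine (Mus musculus), read by reporter gene assay, with a stated time of 24 h; on this read-out lower numbers stand for an effect already at smaller amounts and higher numbers for an effect only at larger amounts of compound. Among the compounds with values here, compound 1 gives the higher of the two numbers; its only neighbour is compound 2, and the step of a 2.0-fold lower number from compound 1 to compound 2 (0.30 log units; within the scatter) lies within the scatter. Compound 3 `Cc1ccc2nc(NC(=O)CNC(=O)c3nn(-c4ccccc4)c(=O)c4ccccc34)sc2c1` is not yet measured. It differs from compound 1 by methyl in place of chloro on an aromatic carbon. Within the data shown here, the single measured step puts a methoxy in place of hydrogen at a different place, so no measured step bears on this change. In this assay the expected step of a 1.3-fold higher number from compound 1 to compound 3 (0.12 log units; within the scatter) is therefore none beyond the scatter. For compound 3 the estimate is 40 nM, with a range from 15 nM to 110 nM.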

Compound 3, half-maximal effective concentration: 35 nM
Compound 3: middle estimate off by 1.1-fold (0.06 log units), on the high side, and the stated range covers the measured number.
By their numbers in this assay, from the lowest: compounds 2, 1 and 3 (each within the scatter of the next, the first and the last beyond it).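

In this assay, methyl in place of chloro on the six-membered aromatic ring gives a 1.2-fold higher number from compound 1 to compound 3 (0.07 log units; within the scatter). Within the data shown here, this is the only reading at this position, and it shows that chloro is not required here for a number in this range, which compounds 1 and 2 alone could not show. Nothing available explains the result. Still open, on these data alone, is whether this position accepts an amine, a carboxylic acid or a longer chain such as propyl. Plain hydrogen at this place also remains open.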